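The compounds below may be only part of what the source reports. "The series", "measured", "known", "first", "only" and "open" are said of these compounds alone.

In a functional assay on Hs 683 cells (Homo sapiens) for inhibition, read by MTT assay; a higher number here means a weaker inhibitor, a lower number a stronger inhibitor:

- compound 1 `CCCCCCCCCCCC(=O)OC1=C(CC=C(C)C)C(=O)c2ccccc2C1=O`: 18000 nM
- compound 2 `CCCCCCCCCCCCCC(=O)OC1=C(CC=C(C)C)C(=O)c2ccccc2C1=O`: 89000 nM

Both compounds share the same core and differ only in the length of the saturated chain on the ester carbonyl. Compound 2, at 89000 nM, has the higher of the two numbers, which makes it the weaker inhibitor of this pair in this assay.

Compound 3 `CCCCCCCCCCCCCCCC(=O)OC1=C(CC=C(C)C)C(=O)c2ccccc2C1=O` has not yet been measured, and it extends the chain once more: ethyl in place of hydrogen on a saturated chain carbon, ten or more bonds along the chain from a carbonyl carbon. This is ethyl in place of hydrogen on a saturated chain carbon, ten or more bonds along the chain from a carbonyl carbon.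

Within the data shown here, only one measured step bears on this, and it is the same structural change: a 4.9-fold higher number from compound 1 to compound 2 (0.69 log units; beyond the scatter). That step is modest but beyond the scatter, and it points towards weaker inhibition. A single step cannot establish a trend, so a repeat of the same direction is expected, with the size less certain and perhaps somewhat smaller. The expected step is a 2.8-fold higher number from compound 2 to compound 3 (0.45 log units; beyond the scatter).

Compound 3 is estimated at 250000 nM, with an expected range of 90000 nM to 600000 nM.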

Compound 3, half-maximal inhibitory concentration: 48000 nM
For compound 3 the middle estimate is 5.2-fold (0.72 log units) above the measured one; measured number outside the range, below it.
By their numbers in this assay, from the lowest: compound 1; then compounds 3 and 2 (each within the scatter of the next).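

In this assay the same change, ethyl in place of hydrogen on a saturated chain carbon, ten or more bonds along the chain from a carbonyl carbon, now gives a 1.9-fold lower number from compound 2 to compound 3 (0.27 log units; within the scatter) and no longer repeats the earlier 4.9-fold higher number from compound 1 to compound 2 (0.69 log units; beyond the scatter) in size or direction. This means that the change has no fixed effect at this place, and compound 3 goes against any idea that each further extension brings a further loss of inhibition. Butyl in place of hydrogen at the same place still gives a 2.7-fold higher number from compound 1 to compound 3 (0.43 log units; beyond the scatter) overall, so compound 1 stands as the strongest inhibitor of the three, while compound 2 and compound 3 cannot be separated from each other in this assay.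

From the compounds shown here alone, it remains open whether a shorter chain than that of compound 1 would give a lower number, and whether a longer chain than that of compound 3, or a chain carrying an amine or a carboxylic acid, would move the number clearly in either direction. Nothing available explains why the first extension separates the compounds and the second does not.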